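The compounds below may be only part of what the source reports. "The series", "measured", "known", "first", "only" and "open" are said of these compounds alone.

Measured so far in a functional assay on MCF7 cells (Homo sapiens) for antiproliferative activity, with a stated time of 48 h; on this read-out higher numbers stand for weaker inhibition and lower numbers for stronger inhibition: compound 1 `CC(C)(C)c1ccc(CNC(=O)NCCCCl)cc1` gives 17000 nM; compound 2 `CC(C)(C)c1ccc(CNC(=O)NC(=O)CCl)cc1` gives 2800 nM.

Compound 2 stands lowest of these two numbers, reached through the step of a 6.1-fold lower number from compound 1 to compound 2 (0.78 log units; beyond the scatter). Compound 3 `CCNC(=O)NCc1ccc(C(C)(C)C)cc1` differs from compound 2 in one place: ethyl in place of (chloromethyl)carbonyl on an amide-type nitrogen. Within the data shown here, only that one measured step touches the same nitrogen, and it was modest; it moved the number down when (chloromethyl)carbonyl entered, and here that group leaves with nothing comparable entering. For compound 3 the expected step is therefore an 11-fold higher number from compound 2 to compound 3 (1.03 log units; beyond the scatter). Compound 3 is estimated at 30000 nM, with a range from 8000 nM to 100000 nM.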

Compound 3, half-maximal inhibitory concentration: > 100000 nM
Compound 3: only a limit was reported; the forecaster's own chance of this, stated with the estimate: 30%; at least 3.3-fold (0.52 log units) between middle value and limit.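

Taking away the (chloromethyl)carbonyl group costs more than its arrival gained, the step being an at least 35-fold higher number from compound 2 to compound 3 (1.55 log units; beyond the scatter). Taking the chlorine-bearing end off the chain also weakens inhibition, with an at least 5.8-fold higher number from compound 1 to compound 3 (0.76 log units; beyond the scatter), so on this nitrogen both chlorine-bearing groups beat plain ethyl. Compound 3 carries a limit and not a number, so both steps give only a minimum size: the limit of > 100000 nM in this assay, at which 1 of the 3 values shown sits.

As far as these compounds go, whether the chlorine or the carbonyl matters more stays open. An acetyl group, which keeps the carbonyl without chlorine, and a 2-chloroethyl group, which keeps chlorine without carbonyl, would help separate them.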